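The source may report more compounds than this note shows. Statements on the series, on what has been measured and on what is new or still open speak of the compounds shown alone.

Measured in a functional assay on Hep 3B2 cells (Homo sapiens) for inhibition, read by MTT assay, with a stated time of 72 h; a lower number here means a stronger inhibitor, a higher number a weaker inhibitor:
- Compound 1 `CCc1nc2c(C)cc(-c3ccc(CN4CCN(C)CC4)cc3)cn2c1NC(=O)OCc1cc(Cl)cc(Cl)c1`: 4900 nM.
- Compound 2 `CCc1nc2c(C)cc(-c3ccc(CN4CCN(C)CC4)cc3)cn2c1NC(=O)OCc1ccc(C(F)(F)F)cc1`: > 20000 nM, a limit and not a number.

Compound 2 therefore stands only at the limit of > 20000 nM in this assay, at which 1 of the 2 values shown sits. Compound 3 `CCc1nc2c(C)cc(-c3ccc(CN4CCN(C)CC4)cc3)cn2c1NC(=O)OCc1ccc(F)c(F)c1` has 3,4-difluorophenyl in place of 4-(trifluoromethyl)phenyl on a saturated chain carbon bound to an oxygen next to a carbonyl group. Within the data shown here, the one measured step at this place is an at least 4.0-fold higher number from compound 1 to compound 2 (0.61 log units; beyond the scatter), beyond the scatter, and compound 3 no longer carries the group that this step brought in. The expected step in this assay is an at least 1.8-fold lower number from compound 2 to compound 3 (0.25 log units; that floor lies within the scatter), a modest move toward a lower number. For compound 3 the estimated value is 11000 nM, with an expected range of 4000 nM to 30000 nM.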

Compound 3, half-maximal inhibitory concentration: 4940 nM
Estimate against measurement, compound 3: 2.2-fold (0.35 log units) above; measured number inside the range.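

At this place, on a saturated chain carbon bound to an oxygen next to a carbonyl group, the change from 4-(trifluoromethyl)phenyl to 3,4-difluorophenyl gives an at least 4.0-fold lower number from compound 2 to compound 3 (0.60 log units; beyond the scatter). The change from 3,5-dichlorophenyl to 3,4-difluorophenyl gives a 1.0-fold higher number from compound 1 to compound 3 (0.00 log units; within the scatter), so these two halogen-bearing phenyl groups read alike in this assay. Compound 2 is known only as a limit: the limit of > 20000 nM in this assay, at which 1 of the 3 values shown sits.

Still open, as far as these compounds go, is whether the trifluoromethyl group itself or its place on the ring sets compound 2 apart. Also open, from the compounds shown here alone, is whether a methoxy group or an amine on the phenyl ring would read like compound 1 and compound 3.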